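Chain shortening on the alkyne of compound 1

This account rests on a few compounds, and the source may have more. Where it says the series, first, only, none or still open, it means among the compounds named here.

Compound 1 `CCCCC#Cc1c[nH]c(=O)[nH]c1=O` carries a butyl chain on the triple-bonded carbon and bears no sugar. In an ADME assay on A549 cells (Homo sapiens) for cytotoxicity, read by MTT assay (on this read-out higher numbers stand for lower toxicity in this test and lower numbers for higher toxicity in this test), compound 1 gives 250000 nM, the highest of the three numbers recorded. Compound 2 `CCCCCCC#Cc1cn([C@@H]2O[C@H](CO)[C@@H](O)[C@H]2O)c(=O)[nH]c1=O` adds the ribose and a longer chain; in this assay compound 2 gives 87200 nM. Compound 3 `O=c1[nH]c(=O)n([C@@H]2O[C@H](CO)[C@@H](O)[C@H]2O)cc1C#Cc1ccccc1` keeps the ribose but has phenyl on the triple-bonded carbon; in this assay compound 3 gives 42500 nM. For the measured compounds named here, the only single-point step in the set, a 2.1-fold lower number from compound 2 to compound 3 (0.31 log units; beyond the scatter), is a modest drop and concerns a different change from the one considered here. Compound 1 and compound 2 differ in two places, so their gap cannot be assigned to the chain alone.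

Compound 4 `CCC#Cc1c[nH]c(=O)[nH]c1=O` is obtained from compound 1 by the change (hydrogen in place of ethyl on a saturated chain carbon, two bonds along the chain from a triple-bonded carbon). Going by the values given here, no measured step shortens this chain, so the direction is open; the shared core of compound 1 is retained, and the nearest precedent, a change on the alkyne substituent, moved the number only modestly. The expectation for compound 4 in this assay is therefore a step of a 1.2-fold higher number from compound 1 to compound 4 (0.08 log units; within the scatter), within the scatter. Compound 4 is estimated at 300000 nM, with a range from 150000 nM to 600000 nM.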

Compound 4, half-maximal cytotoxic concentration: 253000 nM
Beside the measured number, compound 4's estimate is 1.2-fold (0.07 log units) above it, and the stated range covers the measured number.
By their numbers in this assay, from the lowest: compound 3; then compound 2; then compounds 1 and 4 (each within the scatter of the next).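

Working notes on the chain: with butyl cut back to ethyl on the triple-bonded carbon, the step in this assay is a 1.0-fold higher number from compound 1 to compound 4 (0.01 log units; within the scatter), so this pair shows no measurable response to the loss of the outer ethyl. For the compounds shown here, this is the first single-place reading on the saturated chain itself, and it is taken on the sugar-free shared core, whereas the only earlier single-place step compared hexyl with phenyl on ribose-bearing compounds. Nothing measured here accounts for this flat result.

As far as these compounds go, compound 1 and compound 2 still differ in two places, so their gap cannot be divided between the ribose and the chain, and it remains open whether butyl and ethyl would also read alike with the ribose in place. Also open, from the compounds shown here alone, is whether this position stays as flat when the ethyl is replaced by something other than hydrogen, such as an amine or a carboxylic acid, or whether only a change in the chain's length leaves the number in this range.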